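Swapping a large side chain for a methyl

The compounds below may be only part of what the source reports. "The series", "measured", "known", "first", "only" and "open" are said of these compounds alone.

Measured in a functional assay on NCI-H520 cells (Homo sapiens) for cytotoxicity; on this read-out higher numbers stand for weaker inhibition of growth and lower numbers for stronger inhibition of growth:
- Compound 1 `COc1ccc(C2=C(c3ccc(SC)cc3)CC3CCCN3C2=O)cc1OC(=O)CNC(=O)OC(C)(C)C`: 7000 nM
- Compound 2 `COc1ccc(C2=C(c3ccc(SC)cc3)CC3CCCN3C2=O)cc1OC(=O)C1CCCN1C(=O)OC(C)(C)C`: 5000 nM

Compound 1 and compound 2 lie within the usual scatter of each other, so compound 1 does not stand apart. Compound 3 `COc1ccc(C2=C(c3ccc(SC)cc3)CC3CCCN3C2=O)cc1C` differs from compound 1 by one large change: one carbon atom in place of a group of 12 heavy atoms (7 carbon, 1 nitrogen, 4 oxygen; no ring), on an aromatic carbon. For the measured compounds named here, the only measured step, a 1.4-fold lower number from compound 1 to compound 2 (0.15 log units; within the scatter), altered just part of the group that now leaves, and it stayed within the scatter. No measurement shows what removing the whole group does, so no clear direction can be given for this assay, and the range must stay wide. The expected step is a 1.4-fold lower number from compound 1 to compound 3 (0.15 log units; within the scatter). Compound 3 is estimated at 5000 nM, with an expected range of 600 nM to 30000 nM.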

Compound 3, concentration for 50% growth inhibition: 100 nM
Estimate against measurement, compound 3: 50-fold (1.70 log units) above; measured number below the stated range.
By their numbers in this assay, from the lowest: compound 3; then compounds 2 and 1 (each within the scatter of the next).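

In this assay, the data show a 70-fold lower number from compound 1 to compound 3 (1.85 log units; beyond the scatter) when the large group on this aromatic carbon gives way to a methyl. The group is therefore not needed for growth inhibition in this series, and what sits at this position matters far more than the earlier change within the group suggested. No measurement at hand explains this drop.

On these data alone, whether the gain comes from losing the large group or from gaining the methyl stays open. A hydrogen, a hydroxyl or an ethyl on the same carbon would help separate the two.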